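The source may hold more compounds than are shown below. What is called first, only, known or untested is meant among the compounds shown, and "the series" means these compounds.

Measured so far: compound 1 `CNc1nc(Nc2ccc(C)c([N+](=O)[O-])c2)ncc1C(=O)Nc1cc(NC(=O)c2cccc(OC)c2)ccc1C` with 6310 nM. Compound 2 `CNc1nc(Nc2ccc(C)c(N)c2)ncc1C(=O)Nc1cc(NC(=O)c2ccccc2OC)ccc1C` with > 10000 nM.

In an ADME assay on BaF3 cells (Mus musculus) for antiproliferative activity, read by CellTiter-Glo and CCK-8 assay, with a stated time of 72 h (a higher number here means a weaker inhibitor of growth, a lower number a stronger inhibitor of growth), compound 1 gives 6310 nM. Compound 2 reaches only a limit of this assay, > 10000 nM, so no number stands for it. Its result sits at the limit of > 10000 nM in this assay, at which 1 of the 2 values shown sits. Compound 3 `CNc1nc(Nc2ccc(C)c(N)c2)ncc1C(=O)Nc1cc(NC(=O)c2cccc(OC)c2)ccc1C` is not yet measured. It differs from compound 2 in one place: 3-methoxyphenyl in place of 2-methoxyphenyl on a carbonyl carbon; the two have the same atoms, joined differently. Going by the values given here, no pair of measured compounds differing in a single place is available, so the size of this step cannot be read from the data; compound 1 and compound 2 differ in more than one place and show only that one sits at a number while the other sits at a limit. The step from compound 2 to compound 3 is expected to be an at least 1.2-fold lower number from compound 2 to compound 3 (0.09 log units; that floor lies within the scatter), a move toward stronger inhibition that may not exceed the scatter. Compound 3 is estimated at 8000 nM, within 3000 nM to 30000 nM.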

Compound 3, concentration for 50% growth inhibition: > 10000 nM
Compound 3: no number, only a limit; the forecaster's own chance of this, stated with the estimate: 45%; at least 1.2-fold (0.09 log units) between middle value and limit.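

Compound 2 and compound 3 both stand at a limit rather than at a number, so in this assay the change from 2-methoxyphenyl to 3-methoxyphenyl on the carbonyl carbon cannot be read: the limit of > 10000 nM in this assay, at which 2 of the 3 values shown sit.

Compound 3 does supply the first pair differing in one place with a number on one side: amino in place of nitro on an aromatic carbon gives an at least 1.5-fold higher number from compound 1 to compound 3 (0.19 log units; that floor lies within the scatter). On these data alone, that floor does not establish a change beyond the usual scatter, and the true size of the step stays unknown.

As far as these compounds go, it remains open whether another group on that carbonyl carbon, such as a plain phenyl or a cyclohexyl, would bring an amino compound to a number. Also open, from the compounds shown here alone, is what a nitrile or an acetamido would give in place of the amino group on the aromatic carbon.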